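A Larger Ester Replaces the Acid on the Core

The source may hold more compounds than are shown below. What is called first, only, known or untested is meant among the compounds shown, and "the series" means these compounds.

Compound 2 `Nc1ccc(-c2cc(=O)c3c(N)c(F)c(C(=O)O)c(F)c3o2)cc1F` carries a carboxy group on its core. In a functional assay on HeLa cells (Homo sapiens) for cytotoxicity, read by neutral red uptake, with a stated time of 3 days (a higher number here means a weaker inhibitor, a lower number a stronger inhibitor), compound 2 gives > 100000 nM, which is a limit of the assay rather than a number. Its closest measured relative, compound 1 `Nc1ccc(-c2cc(=O)c3c(N)c(F)cc(F)c3o2)cc1F`, lacks that group. In this assay compound 1 gives > 100000 nM, again a limit. The step that the two limits leave unreadable from compound 1 to compound 2 therefore cannot be read in size, since (the limit of > 100000 nM in this assay, at which 2 of the 2 values shown sit). The change to compound 3 `CN(C)CCCC(=O)OCc1c(F)c(N)c2c(=O)cc(-c3ccc(N)c(F)c3)oc2c1F` is (((3-(dimethylamino)propyl)carbonyl)oxy)methyl in place of carboxy on an aromatic carbon. Within the data shown here, no measured step bears on it: the only one recorded, from compound 1 to compound 2, is unreadable, and both values sit at the limit. Compound 3 is expected to remain near the same mark, so the expected step is a number no higher from compound 2 to compound 3 (the limit leaves the size open). The estimate for compound 3 is 100000 nM, within a range from 30000 nM to 300000 nM.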

Compound 3, half-maximal inhibitory concentration: 4500 nM
The estimate for compound 3 lay 22-fold (1.35 log units) above the measured number, and the stated range ends above it.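

This position on the shared core, ortho to two fluoro groups, can change the read-out in this assay: (((3-(dimethylamino)propyl)carbonyl)oxy)methyl in place of carboxy gives an at least 22-fold lower number from compound 2 to compound 3 (1.34 log units; beyond the scatter), and the same group in place of hydrogen gives an at least 22-fold lower number from compound 1 to compound 3 (1.34 log units; beyond the scatter). The earlier pair showed no such change, and its step cannot be read. Both new steps have only a lower end, because each starts from a limit: the limit of > 100000 nM in this assay, at which 2 of the 3 values shown sit.

The compounds shown do not take the new group apart, so it stays open which part of it goes with the lower number: the dimethylamino end, the carbonyl or the chain. A primary amine at the chain end or a shorter chain would begin to separate these parts.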